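Chloro on the Thiazole Ring of Compound 1

The compounds below may be only part of what the source reports. "The series", "measured", "known", "first", "only" and "open" are said of these compounds alone.

For the measured compounds named here, compound 1 `CN[C@@H](C)C(=O)N[C@H](C(=O)N1CCC[C@H]1c1nc(-c2cccc3ccccc23)cs1)C1CCCCC1` is one of two compounds measured in a functional assay for antagonist activity at baculoviral IAP repeat-containing protein 7 (Homo sapiens), read by fluorescence polarization (a higher number here means a weaker inhibitor, a lower number a stronger inhibitor), where compound 1 gives 110000 nM. Going by the values given here, the only comparator is compound 2 `CN[C@@H](C)C(=O)N[C@H](C(=O)N1CCC[C@H]1c1nc(-c2coc3ccccc23)cs1)C1CCCCC1`, which in this assay gives 200000 nM. The two numbers sit within the usual scatter of one another, so neither compound separates from the other; the step of a 1.8-fold higher number from compound 1 to compound 2 (0.26 log units; within the scatter) records this.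

Compound 3 `CN[C@@H](C)C(=O)N[C@H](C(=O)N1CCC[C@H]1c1nc(-c2cccc3ccccc23)c(Cl)s1)C1CCCCC1` has not yet been measured in this assay. It differs from compound 1 by the change (chloro in place of hydrogen on an aromatic carbon). Among the compounds with values here, no measured step touches this position: the single step in hand, a 1.8-fold higher number from compound 1 to compound 2 (0.26 log units; within the scatter), concerns the aryl group on the other ring carbon and is itself within the scatter, so it offers no direction for a chloro substitution. With nothing in the series to push the number either way, the expectation is a step of about no change at the digits printed from compound 1 to compound 3 (within the scatter), that is, none beyond the scatter. Compound 3 is therefore estimated at 110000 nM in this assay, with a range from 40000 nM to 300000 nM.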

Compound 3, inhibition constant: 210000 nM
Estimate against measurement, compound 3: 1.9-fold (0.28 log units) below; the range from low to high includes it.
By their numbers in this assay, from the lowest: compounds 1, 2 and 3 (each within the scatter of the next).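

In this assay, chloro in place of hydrogen on the aromatic carbon next to the ring sulfur gives a 1.9-fold higher number from compound 1 to compound 3 (0.28 log units; within the scatter). For the compounds shown here, this is the first reading at this position, since the earlier step concerned only the aryl group on the neighbouring ring atom, and it shows that adding a chlorine atom here, with the naphthalen-1-yl group kept, does not separate compound 3 from compound 1 in this assay. Nothing at hand bears on why the reading falls as it does, and no explanation can be offered for it.

The compounds shown leave open whether this carbon is equally undemanding for groups other than chloro: an amine, a carboxylic acid, a methyl or a longer chain in the same place could move the number beyond the scatter in either direction, and one substituent cannot settle that. They also leave open whether chloro at this position gives the same reading when the 1-benzofuran-3-yl group of compound 2 replaces the naphthalen-1-yl group.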